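This account rests on a few compounds, and the source may have more. Where it says the series, first, only, none or still open, it means among the compounds named here.

In an assay on HEK293 cells for positive allosteric modulation of metabotropic glutamate receptor 2 (Rattus norvegicus), read by thallium flux, with a stated time of 2.5 min (on this read-out lower numbers stand for smaller maximal responses and higher numbers for larger maximal responses), compound 2 `Cc1c(OCCCCOc2ccc(C(=O)O)cc2F)ccc(C(=O)CC2CCCC2)c1O` gives 83.8%, and compound 1 `Cc1c(OCCCCOc2ccc(C(=O)O)cc2)ccc(C(=O)CC2CCCC2)c1O` gives 82.6%; the two numbers lie within the usual scatter of each other, as the step of a number 1.2 percentage points higher from compound 1 to compound 2 (within the scatter) shows. Compound 3 `Cc1c(OCCCCOc2ccc(C(=O)O)cc2F)ccc(C(=O)CC(C)C)c1O` differs from compound 2 by isopropyl in place of cyclopentyl on a saturated chain carbon bound to a carbonyl carbon. Among the compounds with values here, the only measured step concerns a fluoro on an aromatic carbon, far from this place, so it says nothing about this change. Nothing beyond the scatter is therefore expected, and the estimated step is a number 1.8 percentage points lower from compound 2 to compound 3 (within the scatter). Compound 3 is expected to give about 82%, most likely between 68% and 96%.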

Compound 3, largest response reached (reported as percent of maximum), in percent of the reference or control that the assay uses: 85%
Compound 3: the middle estimate sits 3 percentage points below what was measured; the range from low to high includes it.
By their numbers in this assay, from the lowest: compounds 1, 2 and 3 (each within the scatter of the next).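

Putting isopropyl in place of cyclopentyl on a saturated chain carbon bound to a carbonyl carbon gives a number 1.2 percentage points higher from compound 2 to compound 3 (within the scatter). At this place, then, the maximal response does not depend on the five-membered ring: a group of 3 heavy atoms without a ring serves as well as one of 5 heavy atoms with a ring. No evidence on the reason for this is at hand. From the compounds shown here alone, it remains open whether a much smaller methyl, a larger phenyl or a chain ending in an amine would fit here equally well.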